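Removing One Methoxy From the Ketone-Side Ring

This account rests on a few compounds, and the source may have more. Where it says the series, first, only, none or still open, it means among the compounds named here.

Measured compounds:
Compound 1, `COc1cc(-c2cc(/C=C/C(=O)c3ccc(N)cc3)[nH]n2)cc(OC)c1OC`: 93%
Compound 2, `COc1cc(-c2cc(/C=C/C(=O)c3ccc(Cl)c(Cl)c3)[nH]n2)cc(OC)c1OC`: 96%
Compound 3, `COc1ccc(C(=O)/C=C/c2cc(-c3cc(OC)c(OC)c(OC)c3)n[nH]2)cc1OC`: 89%

All three were tested in a functional assay on UACC-257 cells (Homo sapiens) for cytotoxicity, read by sulforhodamine B assay, with a stated time of 48 h, tested at 0.1 uM; a higher number here means a weaker effect of the compound at the concentration tested, a lower number a stronger effect. Compound 3 carries the smallest of the three numbers, yet both gaps, a number 4 percentage points lower from compound 1 to compound 3 (within the scatter) and a number 7 percentage points lower from compound 2 to compound 3 (within the scatter), lie within the scatter, so the three compounds cannot be told apart on these numbers.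

Compound 4, `COc1ccc(C(=O)/C=C/c2cc(-c3cc(OC)c(OC)c(OC)c3)n[nH]2)cc1`, has not yet been measured. It differs from compound 3 in one place: hydrogen in place of methoxy on an aromatic carbon. The change again sits on the ring attached to the carbonyl, the same ring that was varied in every measured step. Those steps, a number 3 percentage points higher from compound 1 to compound 2 (within the scatter), a number 4 percentage points lower from compound 1 to compound 3 (within the scatter) and a number 7 percentage points lower from compound 2 to compound 3 (within the scatter), all stayed within the scatter, whether amino, chlorine or methoxy groups were present on that ring. For the measured compounds named here, no measured step shows that the number of methoxy groups on this ring matters. The expected step from compound 3 to compound 4 is therefore a number 1 percentage points higher from compound 3 to compound 4 (within the scatter), none beyond the scatter. Compound 4 is estimated to give 90%, within a range from 80% to 100%.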

Compound 4, a percentage reported as activity, at one concentration (the size of the read-out at that concentration, not a potency): 97%
Estimate against measurement, compound 4: 7 percentage points below; the measured number falls inside the stated range.
By their numbers in this assay, from the lowest: compounds 3, 1, 2 and 4 (each within the scatter of the next).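

In this assay, going from 3,4-dimethoxyphenyl to 4-methoxyphenyl gives a number 8 percentage points higher from compound 3 to compound 4 (within the scatter) and so shows that this ring does not need its second methoxy group for compound 4 to stay level with compound 3 at this concentration. This is the only step shown that removes a group from the ring and puts nothing larger than hydrogen in its place, and the comparisons with the other rings, a number 1 percentage points higher from compound 2 to compound 4 (within the scatter) and a number 4 percentage points higher from compound 1 to compound 4 (within the scatter), likewise leave compound 4 indistinguishable from the rest. Nothing measured here explains these numbers.

On these data alone, all four compounds lie close together at this single concentration, so it remains open whether changes on this ring matter under conditions where the compounds differ more clearly. As far as these compounds go, it also remains open how a hydroxy group, a carboxylic acid or a bare phenyl ring would behave in this position.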